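Series notes: exposure after oral cassette dosing, monkey

The source may report more compounds than this note shows. Statements on the series, on what has been measured and on what is new or still open speak of the compounds shown alone.

Measured compounds:
compound 1 `CCCCN(c1nc2c(NS(C)(=O)=O)cccc2o1)[C@H](C)c1ccc(-c2ccccc2-c2nnn[nH]2)cc1` gives 73.8 ng.h/mL
compound 2 `CCCCN(c1nc2c(-c3nccn3C)cccc2o1)[C@H](C)c1ccc(-c2ccccc2-c2nnn[nH]2)cc1` gives 152 ng.h/mL
compound 3 `CCCCN(c1nc2c(C(=O)NS(C)(=O)=O)cccc2o1)[C@H](C)c1ccc(-c2ccccc2-c2nnn[nH]2)cc1` gives 22.2 ng.h/mL

In an ADME assay on the whole organism (Macaca fascicularis) for pharmacokinetics, read by LC-MS, using cassette dosing, at a dose of 1 mg/kg by the oral route (on this read-out lower numbers stand for lower exposure and higher numbers for higher exposure at the dose given), compound 3 stands lowest of the three, with the gap a 3.3-fold lower number from compound 1 to compound 3 (0.52 log units; beyond the scatter) and the larger gap a 6.8-fold lower number from compound 2 to compound 3 (0.84 log units; beyond the scatter), both beyond the scatter. Compound 1 to compound 2 also moved, a 2.1-fold higher number from compound 1 to compound 2 (0.31 log units; beyond the scatter).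

The next compound is compound 4 `CCCCN(c1nc2c(NC(C)=O)cccc2o1)[C@H](C)c1ccc(-c2ccccc2-c2nnn[nH]2)cc1`. The change from compound 3 is acetamido in place of (methylsulfonyl)carbamoyl on an aromatic carbon. Within the data shown here, none of the measured steps covers this exact swap. The nearest guide is compound 1, whose methanesulfonamido carries the same donor count as acetamido, and the step of a 3.3-fold lower number from compound 1 to compound 3 (0.52 log units; beyond the scatter) shows that the (methylsulfonyl)carbamoyl group is the one attached to the lowest number here. Compound 2 shows that the same position tolerates a group without a donor and gives the highest number.

Removing the (methylsulfonyl)carbamoyl is therefore expected to raise this assay, with the step estimated at a 2.7-fold higher number from compound 3 to compound 4 (0.43 log units; beyond the scatter), in the direction of compound 1 because of a 3.3-fold lower number from compound 1 to compound 3 (0.52 log units; beyond the scatter). The estimate for compound 4 in this assay is 60 ng.h/mL, in a range from 20 ng.h/mL to 180 ng.h/mL.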

Compound 4, area under the concentration-time curve: 41.6 ng.h/mL
Compound 4: the middle estimate sits 1.4-fold (0.16 log units) above what was measured; the range from low to high includes it.
By their numbers in this assay, from the lowest: compounds 3, 4 and 1 (each within the scatter of the next, the first and the last beyond it); then compound 2.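

In this assay, acetamido on this aromatic carbon cannot be separated from either sulfonyl-bearing group, with a 1.9-fold higher number from compound 3 to compound 4 (0.27 log units; within the scatter) and a 1.8-fold lower number from compound 1 to compound 4 (0.25 log units; within the scatter) both within the scatter, so acetyl in place of methylsulfonyl on the nitrogen gives no readable change and compound 4 bridges the gap that was beyond the scatter between compound 1 and compound 3. The 1-methyl-1H-imidazol-2-yl group remains apart, with a 3.7-fold lower number from compound 2 to compound 4 (0.56 log units; beyond the scatter) beyond the scatter, and compound 2 is now clear of all three compounds that carry an acylated or sulfonylated group at this position. No measured property accompanies these exposure numbers, so the data offer no explanation for the steps.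

As far as these compounds go, whether an amine or a carboxylic acid on this aromatic carbon would fall nearer compound 2 or compound 4 remains open, as does the effect of a longer chain in place of the acetyl methyl. From the compounds shown here alone, it is also open whether the level of compound 2 is specific to 1-methyl-1H-imidazol-2-yl or is shared by another ring such as oxazole or unsubstituted imidazole.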